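Diaryl urea series: the step from compound 3 to compound 4

The source may hold more compounds than are shown below. What is called first, only, known or untested is meant among the compounds shown, and "the series" means these compounds.

Three compounds of the series have numbers in a functional assay on MDA-MB-468 cells (Homo sapiens) for inhibition, read by sulforhodamine B assay, with a stated time of 48 h, tested at 10 uM; a lower number here means a stronger effect, a higher number a weaker effect of the compound at the concentration tested. Compound 1 `COc1cc(Cl)cc(-c2nn(-c3cccc(NC(=O)Nc4ccc(Cl)c(C(F)(F)F)c4)c3)cc2-c2ccncc2)c1` gives -14.4%, compound 2 `COc1cc(Cl)cc(-c2nn(-c3cccc(NC(=O)Nc4cc(C(F)(F)F)cc(C(F)(F)F)c4)c3)cc2-c2ccncc2)c1` gives -2.95%, and compound 3 `COc1cc(Cl)cc(-c2nn(-c3cccc(NC(=O)Nc4ccc(Cl)c(Cl)c4)c3)cc2-c2ccncc2)c1` gives 0.72%. On these numbers compound 3 stands highest of the three; compound 2 lies within the scatter of it, while compound 1 lies beyond the scatter, lower. Within the data shown here, the one single-site step measured so far is a number 15.1 percentage points higher from compound 1 to compound 3 (beyond the scatter).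

Compound 4 `COc1cc(Cl)cc(-c2nn(-c3cccc(NC(=O)Nc4cccc(C(F)(F)F)c4)c3)cc2-c2ccncc2)c1` is not yet measured. It differs from compound 3 by 3-(trifluoromethyl)phenyl in place of 3,4-dichlorophenyl on an amide-type nitrogen. The measured step bears on this only in part: it swapped trifluoromethyl for chloro on the aromatic carbon while the second chloro stayed, whereas here that second chloro also leaves. Compound 4 shares its trifluoromethyl with compound 1 and lacks the chloro that compound 1 carries; compound 2, with two trifluoromethyl groups and no chloro, sits within the scatter of compound 3. The expectation is therefore a move downward from compound 3, smaller than the measured step or within the scatter, estimated as a number 7.7 percentage points lower from compound 3 to compound 4 (within the scatter). For compound 4 the expected value in this assay is -7%, with a range from -22% to 8%.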

Compound 4, a percentage reported as activity, at one concentration (the size of the read-out at that concentration, not a potency): 6.89%
Beside the measured number, compound 4's estimate is 13.9 percentage points below it, within the range that was stated.
By their numbers in this assay, from the lowest: compound 1; then compounds 2, 3 and 4 (each within the scatter of the next).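

In this assay, 3-(trifluoromethyl)phenyl in place of 3,4-dichlorophenyl on an amide-type nitrogen gives a number 6.2 percentage points higher from compound 3 to compound 4 (within the scatter), so this two-site change on the aryl ring of the urea does not separate the two compounds. The single removals differ in how they read: loss of one of the two trifluoromethyl groups gives a number 9.8 percentage points higher from compound 2 to compound 4 (within the scatter), whereas loss of the chloro gives a number 21.3 percentage points higher from compound 1 to compound 4 (beyond the scatter). Among the steps that end at compound 4, only the one from compound 1 lies beyond the scatter, and it adds a second step out of compound 1 of that kind; nothing available accounts for this difference.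

The compounds shown leave open how this position reads with an amine, a carboxylic acid or a nitrile on the aryl ring, since every substituent present there is a chloro or a trifluoromethyl. They also leave open whether these differences in effect would hold at other concentrations, since each number here is the size of the read-out at one concentration.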